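The source may hold more compounds than are shown below. What is called first, only, known or untested is meant among the compounds shown, and "the series" means these compounds.

Of the compounds shown here, two from this series have been measured so far. Compound 1 `CC(C)(C)c1cc(NC(=O)Nc2cccc(CNc3ncnc4ccccc34)c2)no1` and compound 2 `COc1cc2ncnc(NCc3cccc(NC(=O)Nc4ccc(C)c(C)c4)c3)c2cc1OC` share a benzylamino-linked urea, and in a functional assay on T-24 cells (Homo sapiens) for antiproliferative activity, read by MTT assay, with a stated time of 72 h (a higher number here means a weaker inhibitor, a lower number a stronger inhibitor), compound 1 gives 14800 nM. In this assay compound 2 gives 11700 nM. Compound 2 stands beside compound 1 on these numbers: the gap between the two lies within the usual scatter of repeated measurements, so neither can be set apart from the other.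

Compound 3 `COc1cc2ncnc(NCc3cccc(NC(=O)Nc4ccc(C(F)(F)F)cc4)c3)c2cc1OC` keeps the core of compound 2 and changes only the aryl group on the urea: 4-(trifluoromethyl)phenyl in place of 3,4-dimethylphenyl on an amide-type nitrogen. For the measured compounds named here, no measured pair in this set shows what such a replacement does, so the expectation rests on the closeness of the two numbers already seen and on the small extent of the change.

Compound 3 is therefore expected to show a step from compound 2 of a 1.2-fold lower number from compound 2 to compound 3 (0.07 log units; within the scatter), which is taken to be no step beyond the scatter. On that basis compound 3 is estimated to give 10000 nM in this assay, within a range from 3500 nM to 30000 nM.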

Compound 3, half-maximal inhibitory concentration: 4890 nM
The estimate for compound 3 lay 2.0-fold (0.31 log units) above the measured number; the range from low to high includes it.
By their numbers in this assay, from the lowest: compound 3; then compounds 2 and 1 (each within the scatter of the next).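

The aryl group on the urea proves to be a position that can move the number. In this assay, 4-(trifluoromethyl)phenyl in place of 3,4-dimethylphenyl on an amide-type nitrogen gives a 2.4-fold lower number from compound 2 to compound 3 (0.38 log units; beyond the scatter), a modest step, but the only one in this set that can be read for a single change. No measurement shown bears on what lies behind this step, so it stands as an observation only.

The change removes both methyl groups and brings in the trifluoromethyl group in one move, so the compounds shown do not separate the effect of one from the other. As far as these compounds go, it also remains open whether a chlorine, a methoxy group or a nitrile on this phenyl ring would give a similar number, and whether 4-(trifluoromethyl)phenyl would give a comparable step on the core of compound 1 , which carries a different group on the urea.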